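From chloro to propyl on a shared aromatic end

The compounds below may be only part of what the source reports. "The series", "measured", "known", "first", "only" and "open" are said of these compounds alone.

Within the data shown here, in a functional assay on the whole organism for inhibition, with Rattus norvegicus as the target (a lower number here means that less compound is needed, a higher number that more compound is needed for the effect), compound 1 `CC(Cc1ccc(Cl)cc1)(Oc1ccc(Cc2ccccc2)cc1)C(=O)O` gives 1 mg/kg, the only true number among the values so far. Compound 2 `CC(Cc1ccc(Cl)cc1)(Oc1ccc(Cc2ccc(Cl)cc2)cc1)C(=O)O` is reported as > 10 mg/kg, which is a limit. Compound 3 `CC(Cc1ccc(Cl)cc1)(Oc1ccc(Br)cc1)C(=O)O` is reported as < 1 mg/kg, which is also a limit.

Compound 4 `CCCc1ccc(CC(C)(Oc2ccc(Cc3ccccc3)cc2)C(=O)O)cc1` keeps the core of compound 1 but turns 4-chlorophenyl into 4-propylphenyl, with propyl in place of chloro on an aromatic carbon, para to a large group: propyl in place of chloro on an aromatic carbon.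

Among the measured compounds shown here, no measured step touches this group, which compounds 1, 2 and 3 all carry, so the evidence is indirect. Elsewhere in the molecule, chloro in place of hydrogen gives an at least 10-fold higher number from compound 1 to compound 2 (1.00 log units; beyond the scatter), so one small addition can cost a lot. Bromo in place of benzyl gives a number no higher from compound 1 to compound 3 (the limit leaves the size open), and bromo in place of 4-chlorobenzyl gives an at least 10-fold lower number from compound 2 to compound 3 (1.00 log units; beyond the scatter). These show that this assay responds strongly to changes at that other end, but they say nothing direct about the propyl swap.

A modest rise in the number is therefore expected, smaller than the step to compound 2, and with real uncertainty. The expected change is a 3.0-fold higher number from compound 1 to compound 4 (0.48 log units; beyond the scatter). For compound 4 the estimate is 3 mg/kg, with an expected range from 0.7 mg/kg to 15 mg/kg.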

Compound 4, dose for half-maximal effect: 1 mg/kg
The estimate for compound 4 lay 3.0-fold (0.48 log units) above the measured number; low and high end bracket the measured number.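

In this assay, among these compounds, the change from 4-chlorophenyl to 4-propylphenyl gives no change at the digits printed from compound 1 to compound 4 (within the scatter) and is the only measured step at this end of the molecule. On this aromatic ring, para to a large group, a propyl chain of 3 carbon atoms can therefore stand where a single chlorine atom stood, and the dose needed for the effect stays where it was. At the other end of the molecule, a single added chloro gives an at least 10-fold higher number from compound 1 to compound 2 (1.00 log units; beyond the scatter) and the size of that step rests on a limit, so in these compounds a small change does not count the same at both ends.

From the compounds shown here alone, whether this position accepts other groups also stays open: plain hydrogen, an amine, a carboxylic acid or a longer chain such as hexyl could each read differently from chloro and propyl. Nothing in the data shown explains why chloro and propyl give the same reading here.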